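This account rests on a few compounds, and the source may have more. Where it says the series, first, only, none or still open, it means among the compounds named here.

Compound 2 `COc1ccc(C(=O)c2cc(OC)c(OC)c(OC)c2)cc1NC(=O)/C=C/c1cccc(OC(F)(F)F)c1` gives 7700 nM in a functional assay on PC-3 cells (Homo sapiens) for cytotoxicity, read by MTT assay, with a stated time of 72 h (a higher number here means a weaker inhibitor, a lower number a stronger inhibitor), the higher of the two numbers measured, while compound 1 `COc1ccc(C(=O)c2cc(OC)c(OC)c(OC)c2)cc1NC(=O)/C=C/c1cc(OC)c(OC)c(OC)c1` gives 3900 nM. Among the compounds with values here, the only measured step, a 2.0-fold higher number from compound 1 to compound 2 (0.30 log units; within the scatter), shows that swapping the aryl group on the chain moved the number little. Compound 3 `COc1ccc(C(=O)c2cc(OC)c(OC)c(OC)c2)cc1NC(=O)/C=C/c1ccc(F)c(F)c1` carries 3,4-difluorophenyl in place of 3-(trifluoromethoxy)phenyl on a double-bonded chain carbon bound to a double-bonded chain carbon. Within the data shown here, no measured step covers this particular exchange, and the one step available was within the scatter, so a step of no more than the scatter is expected in either direction, a 1.1-fold lower number from compound 2 to compound 3 (0.04 log units; within the scatter). Compound 3 is therefore estimated at 7000 nM, within a range of 2500 nM to 20000 nM.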

Compound 3, half-maximal inhibitory concentration: 8300 nM
Estimate against measurement, compound 3: 1.2-fold (0.07 log units) below; measured number inside the range.
By their numbers in this assay, from the lowest: compounds 1, 2 and 3 (each within the scatter of the next, the first and the last beyond it).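

In this assay, exchanging 3-(trifluoromethoxy)phenyl for 3,4-difluorophenyl on a double-bonded chain carbon gave a 1.1-fold higher number from compound 2 to compound 3 (0.03 log units; within the scatter) and so did not separate these two groups. Within the data shown here, exchanging 3,4,5-trimethoxyphenyl for 3,4-difluorophenyl gave a 2.1-fold higher number from compound 1 to compound 3 (0.33 log units; beyond the scatter) as the first step at this place to pass the scatter, and only modestly. Nothing available explains either step. As far as these compounds go, whether an amine or a carboxylic acid on this phenyl would move the number further remains open, as does the effect of an unsubstituted phenyl.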